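The source may hold more compounds than are shown below. What is called first, only, known or untested is meant among the compounds shown, and "the series" means these compounds.

Compound 1 `CC1(C(c2ccccc2)c2ccccc2)OS(=O)(=O)C=C1OCc1ccccc1` sits at a limit of an ADME assay on HEL cells (Homo sapiens) for cytotoxicity, with a stated time of 3 days; on this read-out lower numbers stand for higher toxicity in this test and higher numbers for lower toxicity in this test: compound 1 gives >= 400000 nM. Compound 2 `CCC1(Cc2ccccc2)OS(=O)(=O)C=C1OC` likewise reaches a limit; compound 2 gives > 400000 nM. Compound 3 `CC1(Cc2ccccc2)OS(=O)(=O)C=C1OCc1ccccc1` is at a limit too, and compound 3 gives > 400000 nM.

Compound 2 therefore stands at the limit where most values sit (the limit of > 400000 nM in this assay, at which 2 of the 3 values shown sit), so only a range is known for it. Going by the values given here, the one measured step, a step that the two limits leave unreadable from compound 1 to compound 3, is unreadable. Compound 4 `CCC1(Cc2ccccc2)OS(=O)(=O)C=C1OCCCc1ccccc1` differs from compound 2 by phenethyl in place of hydrogen on a saturated chain carbon bound to an oxygen on an unsaturated carbon. Among the compounds with values here, no measured step bears on this change, and the unreadable step gives no size to carry over. Compound 4 is therefore expected to remain near the limit, with an expected step of a number no higher from compound 2 to compound 4 (the limit leaves the size open). Compound 4 is estimated at 400000 nM, between 100000 nM and 800000 nM.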

Compound 4, minimum cytotoxic concentration: >= 20000 nM
Compound 4: a limit, no number; the forecaster's own chance of this, stated with the estimate: 70%; the middle value lies beyond the limit too.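

In this assay compound 2 and compound 4 both stand at limits, and no step can be read between them. The compounds shown leave open how far phenethyl in place of hydrogen shifts toxicity, if at all.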